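Replacing the aryl ketone of compound 2 with an acetal

The compounds below may be only part of what the source reports. "The series", "measured", "known", "first", "only" and "open" are said of these compounds alone.

Measured compounds:
compound 1 `CCCCCCCC/C=C\CCCCCCC(=O)c1nc2cnccc2o1` gives 7.2 nM in an assay on isolated protein for inhibition of Fatty-acid amide hydrolase 1 (Homo sapiens); on this read-out lower numbers stand for stronger inhibition and higher numbers for weaker inhibition
compound 2 `CCCCCCCC/C=C\CCCCCCC(=O)c1ccccc1` gives > 100000 nM in this assay
compound 3 `CCCCCCCC/C=C\CCCCCCC(=O)c1nc2cccnc2o1` gives 11 nM in this assay

Compound 2 stands apart from the other two: its value is a limit of the assay, not a number, and it sits at the limit of > 100000 nM in this assay, at which 1 of the 3 values shown sits. Compound 1 and compound 3 give numbers, and the step of a 1.5-fold higher number from compound 1 to compound 3 (0.18 log units; within the scatter) is small, whereas an at least 13000-fold higher number from compound 1 to compound 2 (4.14 log units; beyond the scatter) and an at least 9000-fold lower number from compound 2 to compound 3 (3.95 log units; beyond the scatter) are both large. Compound 4 `CCCCCCCC/C=C\CCCCCCCC(OC)OC` differs from compound 2 by 2,2-dimethoxyethyl in place of benzoyl on a saturated chain carbon, six bonds along the chain from a double-bonded chain carbon. Among the compounds with values here, no measured step exchanges a benzoyl for a 2,2-dimethoxyethyl, so the only steps that bear on this one are those that reach compound 2 itself, an at least 13000-fold higher number from compound 1 to compound 2 (4.14 log units; beyond the scatter) and an at least 9000-fold lower number from compound 2 to compound 3 (3.95 log units; beyond the scatter), and they show how far compound 2 already lies from the two compounds that give numbers. Within the data shown here, compound 4 keeps none of what those two compounds carry on the carbonyl carbon, and nothing among the measured compounds suggests a return to measurable inhibition. Compound 4 is therefore expected to remain at the limit, and the step of a number no higher from compound 2 to compound 4 (the limit leaves the size open) is expected to be none beyond the scatter. The estimate for compound 4 in this assay is 100000 nM, with a range from 30000 nM to 300000 nM.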

Compound 4, inhibition constant: > 300000 nM
Compound 4 ended at the assay's limit; the forecaster's own chance of this, stated with the estimate: 85%; middle value at least 3.0-fold (0.47 log units) from the limit.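

In this assay compound 4 gives > 300000 nM, which is a limit of the assay and not a number. Within the data shown here, compound 2 also gives only a limit, so no step between compound 2 and compound 4 can be read. The compounds shown leave open whether 2,2-dimethoxyethyl in place of benzoyl changes inhibition at all, and how far either compound lies beyond its limit.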